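The source may hold more compounds than are shown below. What is called first, only, known or untested is meant among the compounds shown, and "the series" means these compounds.

Measured compounds:
Compound 1 `C=CC[C@@H]1C[C@@H](c2ccc(Cl)c(Cl)c2)[C@H](NC(=O)c2cc(-c3c(Cl)cnn3C)c(Cl)o2)CN1`: 160 nM in a functional assay on LNCaP cells (Homo sapiens) for antiproliferative activity; a higher number here means a weaker inhibitor, a lower number a stronger inhibitor.
Compound 2 `Cn1ncc(Cl)c1-c1cc(C(=O)N[C@@H]2CN[C@H](CCNS(C)(=O)=O)C[C@H]2c2ccc(F)c(F)c2)oc1Cl`: 50 nM in this assay.
Compound 3 `CCC[C@@H]1C[C@@H](c2ccc(Cl)c(Cl)c2)[C@H](NC(=O)c2cc(-c3c(Cl)cnn3C)c(Cl)o2)CN1`: "not determined" (no result reported) in this assay.

Of the two numbers available, compound 1 stands highest, and compound 2 gives a lower number, with a gap between them that lies beyond the usual scatter. Compound 4 `Cn1ncc(Cl)c1-c1cc(C(=O)N[C@@H]2CN[C@H](CCCO)C[C@H]2c2ccc(Cl)c(Cl)c2)oc1Cl` differs from compound 1 in one place: 2-hydroxyethyl in place of vinyl on a saturated chain carbon bound to a saturated ring carbon. Within the data shown here, no pair of measured compounds differing in a single place is available, so the size of this step cannot be read from a matched pair. A modest step toward a lower number is expected from compound 1 to compound 4, possibly within the scatter, because compound 2 gives 50 nM. The expected step is a 1.6-fold lower number from compound 1 to compound 4 (0.20 log units; within the scatter). Compound 4 is estimated at 100 nM, within 35 nM to 300 nM.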

Compound 4, half-maximal inhibitory concentration: 210 nM
Compound 4: middle estimate off by 2.1-fold (0.32 log units), on the low side, and the stated range covers the measured number.
By their numbers in this assay, from the lowest: compound 2; then compounds 1 and 4 (each within the scatter of the next).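

In this assay, 2-hydroxyethyl in place of vinyl on a saturated chain carbon bound to a saturated ring carbon gives a 1.3-fold higher number from compound 1 to compound 4 (0.12 log units; within the scatter) as the first single-place step read at this position. Among these compounds, the position therefore carries a chain ending in a hydrogen-bond donor and acceptor with no change beyond the scatter, which the earlier compounds, lacking a matched pair, could not show. No evidence on the reason for this result is available. The compounds shown leave open whether an amine or a carboxylic acid in place of the hydroxyl would move the number beyond the scatter. A longer chain ending in a hydroxyl also remains an open case.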